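The source may report more compounds than this note shows. Statements on the series, on what has been measured and on what is new or still open speak of the compounds shown alone.

Measured so far, in an ADME assay on Vero cells (Chlorocebus sabaeus) for cytotoxicity, read by resazurin assay, with a stated time of 3 days; a higher number here means a weaker inhibitor, a lower number a stronger inhibitor:
Compound 1 `CN(C)c1cc2[nH]c(C3CCCCC3)nc2cc1NC(=O)OCC(F)(F)F` gives > 100 ug/mL, which is a limit of the assay.
Compound 2 `CCCCOC(=O)Nc1cc2nc(C3CCCCC3)[nH]c2cc1N(C)C` gives > 100 ug/mL, which is a limit of the assay.
Compound 3 `CN(C)c1cc2[nH]c(C3CCCCC3)nc2cc1NC(=O)c1ccc(OC(F)F)cc1` gives > 100 ug/mL, which is a limit of the assay.

Among the measured compounds shown here, compound 3 therefore stands where every value so far stands: at the limit of > 100 ug/mL in this assay, at which 3 of the 3 values shown sit. No compound in this set has shown a number inside the assay.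

Compound 4 `CCCOCC(=O)Nc1cc2nc(C3CCCCC3)[nH]c2cc1N(C)C` differs from compound 3 in one place: propoxymethyl in place of 4-(difluoromethoxy)phenyl on a carbonyl carbon.

For the measured compounds named here, the steps that bear on this change are a step that the two limits leave unreadable from compound 1 to compound 3, a step that the two limits leave unreadable from compound 2 to compound 3 and a step that the two limits leave unreadable from compound 1 to compound 2; none of them can be sized, because both ends sit at the limit. Nothing in these data points to any compound leaving the limit. Compound 4 is therefore expected to show no readable step in this assay, with a number no higher from compound 3 to compound 4 (the limit leaves the size open) as the estimated change. The estimated value for compound 4 is 100 ug/mL, expected between 50 ug/mL and 200 ug/mL.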

Compound 4, half-maximal inhibitory concentration: < 50 ug/mL
Compound 4 was reported as a limit; the forecaster's own chance of this, stated with the estimate: 85%; at least 2.0-fold (0.30 log units) between middle value and limit.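

In this assay, among the compounds shown here, the group on the carbonyl carbon is the first change here with a readable step. Putting propoxymethyl in place of 4-(difluoromethoxy)phenyl gives an at least 2.0-fold lower number from compound 3 to compound 4 (0.30 log units; that floor lies within the scatter), in place of butoxy gives an at least 2.0-fold lower number from compound 2 to compound 4 (0.30 log units; that floor lies within the scatter), and in place of 2,2,2-trifluoroethoxy gives an at least 2.0-fold lower number from compound 1 to compound 4 (0.30 log units; that floor lies within the scatter). The steps among compounds 1, 2 and 3 cannot be read, and compound 4 is the only one at the lower limit: the limit of < 50 ug/mL in this assay, at which 1 of the 4 values shown sits.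

Going by these compounds, every value shown is still a limit, so the true size of these steps stays open. Also open, on these data alone, is whether a longer ether chain or an amine on that carbonyl carbon would give a number inside the assay.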